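From compound 3 to compound 4: a swap at the limit

The source may hold more compounds than are shown below. What is called first, only, known or untested is meant among the compounds shown, and "the series" means these compounds.

Three compounds have been measured in an ADME assay on microsomes from liver (Mus musculus) for metabolic stability, read by LC-MS, with NADPH named in the record, with a stated time of 60 min, tested at 1 uM, in the absence of a further agent (a lower number here means that less of the compound is left, a higher number that more of the compound is left), so far:

compound 1 `CC(=O)N[C@@H]1CCN(c2cc(C)nn3c(-c4ccc(C#N)cc4)c(C)nc23)C1` gives > 95% as a limit
compound 2 `COc1cc(-c2c(C)nc3c(N4CC[C@@H](NC(C)=O)C4)cc(C)nn23)ccc1F` gives > 95% as a limit
compound 3 `CC(=O)N[C@@H]1CCN(c2cc(C)nn3c(-c4ccco4)c(C)nc23)C1` gives > 95% as a limit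

Compound 3 stands at the limit of > 95% in this assay, at which 3 of the 3 values shown sit, and so has no exact number of its own. Compound 4 `CC(=O)N[C@@H]1CCN(c2cc(C)nn3c(-c4ccc5cc[nH]c5c4)c(C)nc23)C1` carries 1H-indol-6-yl in place of the furan-2-yl of compound 3 on an aromatic carbon 1H-indol-6-yl in place of furan-2-yl on an aromatic carbon and is otherwise the same.

All three measured steps exchange the group at this same place. They are a step that the two limits leave unreadable from compound 1 to compound 3 and a step that the two limits leave unreadable from compound 2 to compound 3 and also a step that the two limits leave unreadable from compound 1 to compound 2 and none of them has a readable size. They show no drop, but they give no measure of how far a new group could move the result.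

Resting on compound 3 with > 95% as a limit, a small downward step or none beyond the scatter is expected. The expected size is a number at least 5 percentage points lower from compound 3 to compound 4 (that floor lies within the scatter) and this is only an estimate. In this assay the expected value for compound 4 is 90% within an estimated range of 70% to 100% for now.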

Compound 4, percent of the compound remaining: > 95%
Compound 4: only a limit was reported (the forecaster's own chance of this, stated with the estimate: 50%); middle value at least 5 percentage points from the limit.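

In this assay compound 4 gives > 95%, which is a limit. Its steps from compound 1, compound 2 and compound 3 therefore cannot be read, as all of them end at the same limit: the limit of > 95% in this assay, at which 4 of the 4 values shown sit.

The compounds shown leave open how these four rank against one another and whether any group at this place would give a readable number.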